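The source may report more compounds than this note shows. Statements on the series, on what has been measured and on what is new or still open speak of the compounds shown alone.

In a functional assay on the whole organism for activation, with Mus musculus as the target (a higher number here means that more compound is needed for the effect, a lower number that less compound is needed), compound 1 `CCCCCCCCc1ccc2c(c1)CC[C@H](C(N)(CO)CO)C2` gives 3.8 mg/kg, the higher of the two actual numbers in the series. Compound 3 `CCCCCCCCc1ccc2c(c1)CC[C@@H]([C@@](C)(N)CO)C2` gives 0.8 mg/kg, a gap beyond the scatter. Compound 2 `CCCCCCCCc1ccc2c(c1)CC[C@@H]([C@](C)(N)CO)C2` gives > 5 mg/kg, which is a limit and not a number.

Compound 4 `CCCCCCCCc1ccc2c(c1)CC[C@H]([C@@](C)(N)CO)C2` has 1-amino-1-(hydroxymethyl)ethyl in place of 1-amino-2-hydroxy-1-(hydroxymethyl)ethyl on a saturated ring carbon. It has the same atoms and bonds as compounds 2 and 3. Its saturated chain carbon is drawn as in compound 3, while its saturated ring carbon is drawn the opposite way.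

Within the data shown here, the one measured step is an at least 6.2-fold lower number from compound 2 to compound 3 (0.79 log units; beyond the scatter), beyond the scatter, and it stands out because of the fact that compounds 2 and 3 differ only in the configuration as drawn. Among the measured compounds shown here, this favours the chain configuration of compound 3 at 0.8 mg/kg, but no measured step covers the ring carbon, so only part of that gain is carried over.

A modest move to a lower number in this assay is expected, estimated as a 2.5-fold lower number from compound 1 to compound 4 (0.40 log units; beyond the scatter). For compound 4 the estimate is 1.5 mg/kg, with an expected range of 0.4 mg/kg to 5.5 mg/kg.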

Compound 4, dose for half-maximal effect: 0.1 mg/kg
The estimate for compound 4 lay 15-fold (1.18 log units) above the measured number, and the stated range ends above it.
By their numbers in this assay, from the lowest: compound 4; then compound 3; then compound 1. At a limit, above all of these: compound 2.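

In this assay, inverting the saturated ring carbon gives an 8.0-fold lower number from compound 3 to compound 4 (0.90 log units; beyond the scatter), the first measured step at this position, and it can be tied to that carbon alone for one reason: the fact that compounds 3 and 4 differ only in the configuration as drawn

Inverting both stereocentres gives an at least 50-fold lower number from compound 2 to compound 4 (1.69 log units; beyond the scatter), a step that rests on a limit for compound 2 and not on a number. Exchanging 1-amino-2-hydroxy-1-(hydroxymethyl)ethyl for 1-amino-1-(hydroxymethyl)ethyl on the saturated ring carbon gives a 38-fold lower number from compound 1 to compound 4 (1.58 log units; beyond the scatter), so with both stereocentres drawn as in compound 4 this exchange carries no penalty in this assay.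

On these data alone, the effect of inverting the ring carbon with the chain carbon drawn as in compound 2 stays open. As far as these compounds go, it is also open whether a carboxylic acid or a phosphate ester in place of the hydroxyl of 1-amino-1-(hydroxymethyl)ethyl would keep the low number of compound 4.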